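Methoxy for methyl on the chain: estimate for compound 3

The source may report more compounds than this note shows. Statements on the series, on what has been measured and on what is new or still open speak of the compounds shown alone.

Measured so far:
compound 2 `CCCn1c(CN2CCN(c3ncc(Cl)cn3)CC2)nc2ccccc21` — an assay on CHO cells with metabotropic glutamate receptor 2 (Homo sapiens) as the target, read by FLIPR; on this read-out higher numbers stand for an effect only at larger amounts of compound and lower numbers for an effect already at smaller amounts: 794 nM
compound 1 `Cn1c(CN2CCN(c3nc(Cl)ccc3C(F)(F)F)CC2)nc2cc(C(F)(F)F)ccc21` — this assay: 2000 nM

Compound 2 holds the lowest of the two numbers; compound 1 stands higher, beyond the scatter. Compound 3 `COCCn1c(CN2CCN(c3ncc(Cl)cn3)CC2)nc2ccccc21` differs from compound 2 by methoxy in place of methyl on a saturated chain carbon, two bonds along the chain from an aromatic nitrogen. Going by the values given here, no measured pair shows a change of this kind, so its size is unknown from the data; no step beyond the scatter is expected in either direction. Compound 3 is therefore estimated at 800 nM, with a range from 300 nM to 2500 nM. The expected step is a 1.0-fold higher number from compound 2 to compound 3 (0.00 log units; within the scatter).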

Compound 3, half-maximal effective concentration: 501 nM
The estimate for compound 3 lay 1.6-fold (0.20 log units) above the measured number; low and high end bracket the measured number.
By their numbers in this assay, from the lowest: compounds 3 and 2 (each within the scatter of the next); then compound 1.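

In this assay, going by these compounds alone, methoxy in place of methyl on a saturated chain carbon, two bonds along the chain from an aromatic nitrogen, gives a 1.6-fold lower number from compound 2 to compound 3 (0.20 log units; within the scatter) and so provides the first one-place comparison. This position therefore takes the added oxygen, with its one hydrogen-bond acceptor, without a step beyond the scatter. Nothing available explains this result.

As far as these compounds go, whether a longer chain, an amine or a carboxylic acid at this position would also stay within the scatter remains open.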